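A Fluoro Step From a Limit

The source may report more compounds than this note shows. Statements on the series, on what has been measured and on what is new or still open speak of the compounds shown alone.

Compound 1 `Cn1c(-c2ccccc2)nnc1[S+](C)[O-]` is the starting point in a functional assay on the whole organism for antagonist activity, with Mus musculus as the target; on this read-out lower numbers stand for an effect already at smaller amounts and higher numbers for an effect only at larger amounts of compound. In this assay compound 1 gives > 100 mg/kg, which is a limit of the assay and not a number. Compound 2 `COc1ccc(-c2nnc([S+](C)[O-])n2C)cc1` gives > 100 mg/kg, again only a limit. For the measured compounds named here, the one measured step that bears on the change, a step that the two limits leave unreadable from compound 1 to compound 2, therefore has no readable size, and the evidence amounts to the limit of > 100 mg/kg in this assay, at which 2 of the 2 values shown sit.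

Compound 3 `Cn1c(-c2ccccc2F)nnc1[S+](C)[O-]` carries fluoro in place of hydrogen on an aromatic carbon, ortho to a group of 9 heavy atoms: fluoro in place of hydrogen on an aromatic carbon. With no measured size to carry over, the expectation is loose, and compound 3 may well stay at the limit. The expected change is an at least 2.5-fold lower number from compound 1 to compound 3 (0.39 log units; beyond the scatter), towards smaller doses, and it is only a rough estimate. For compound 3 the estimated dose is 40 mg/kg, with an expected range from 5 mg/kg to 200 mg/kg.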

Compound 3, dose for half-maximal effect: > 200 mg/kg
Compound 3: only a limit was reported; the forecaster's own chance of this, stated with the estimate: 50%; middle value at least 5.0-fold (0.69 log units) away from the limit.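

Compound 1 and compound 3 each give only a limit in this assay, and the step between them, fluoro in place of hydrogen on an aromatic carbon, cannot be read. The compounds shown leave open whether any change on the shared core gives a readable dose.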